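Inverting one ring stereocentre: compound 3 to compound 4

The source may report more compounds than this note shows. Statements on the series, on what has been measured and on what is new or still open speak of the compounds shown alone.

Compound 1 (`CC(C)=CCCC(=O)[C@]1(/C=C/C(C)C)C[C@H](CC=C(C)C)C(C)(C)[C@H](C(=O)c2ccccc2)C1=O`) reads > 10000 nM in a functional assay on A549 cells (Homo sapiens) for cytotoxicity, read by CellTiter-Glo, with a stated time of 5 days (a lower number here means a stronger inhibitor, a higher number a weaker inhibitor), and that is a limit, not a number. Compound 2 (`CC(C)=CCCC(=O)[C@]1(/C=C/C(C)C)C[C@H](CC=C(C)C)C(C)(C)[C@@H](C(=O)c2ccccc2)C1=O`) reads > 10000 nM in this assay and that is also a limit. Compound 3 (`COC(=O)[C@@]1(CC=C(C)C)C[C@H](CC=C(C)C)C(C)(C)[C@H](C(=O)C(C)C)C1=O`) reads > 10000 nM in this assay and so stands only as a limit, without a number to place it.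

Compound 4 (`COC(=O)[C@]1(CC=C(C)C)C[C@H](CC=C(C)C)C(C)(C)[C@H](C(=O)C(C)C)C1=O`) is reached by one change (the two compounds have the same atoms and bonds and differ only in configuration as drawn: 1 of 3 stereo elements differ; a stereocentre at a saturated ring carbon is drawn S in compound 3 and R in compound 4). Nothing leaves and nothing enters.

For the measured compounds named here, the one measured step of this type is a step that the two limits leave unreadable from compound 1 to compound 2 and it also changes configuration only (the fact that compounds 1 and 2 differ only in the configuration as drawn). It gives no size to carry over, and all the values shown sit at the same limit (the limit of > 10000 nM in this assay, at which 3 of the 3 values shown sit). No step beyond the scatter and no direction can therefore be expected from the data. The expected change is a number no higher from compound 3 to compound 4 (the limit leaves the size open) in this assay and it would most likely be unreadable. For compound 4 the estimated value is 10000 nM (expected range 5000 nM to 20000 nM) and a report as a limit is the likeliest outcome.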

Compound 4, half-maximal inhibitory concentration: > 10000 nM
Compound 4 gave a limit, no number; the forecaster's own chance of this, stated with the estimate: 85%; the middle value sits exactly at the limit.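

In this assay compound 3 and compound 4 both stand only as limits, so no step can be read for this inversion of one ring stereocentre. The compounds shown leave open whether configuration at that stereocentre affects the read-out at all: the limit of > 10000 nM in this assay, at which 4 of the 4 values shown sit.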